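This account rests on a few compounds, and the source may have more. Where it says the series, first, only, none or still open, it means among the compounds named here.

Compound 2 `COc1cc2c(Oc3ccc(NC(=O)/C=C/S(=O)(=O)c4ccccc4OC)cc3F)ccnc2cc1OCCCN1CCN(C)CC1` gives 270 nM in a functional assay on HT-29 cells (Homo sapiens) for cytotoxicity, read by MTT assay, with a stated time of 72 h; a lower number here means a stronger inhibitor, a higher number a weaker inhibitor. Among the three measured members it holds the second highest number: compound 1 `COc1cc2c(Oc3ccc(NC(=O)/C=C/S(=O)(=O)c4ccccc4F)cc3F)ccnc2cc1OCCCN1CCN(C)CC1` gives 150 nM, and a 1.8-fold higher number from compound 1 to compound 2 (0.26 log units; within the scatter) lies within the scatter, while compound 3 `COc1ccc(S(=O)(=O)/C=C/C(=O)Nc2ccc(Oc3ccnc4cc(OCCCN5CCN(C)CC5)c(OC)cc34)c(F)c2)cc1` gives 1660 nM, with a 6.1-fold higher number from compound 2 to compound 3 (0.79 log units; beyond the scatter) beyond it. The remaining step, an 11-fold higher number from compound 1 to compound 3 (1.04 log units; beyond the scatter), is the largest in the set. All three measured steps alter the aryl group on the sulfonyl sulfur and leave the rest of the shared core untouched.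

Compound 4 `COc1cc2c(Oc3ccc(NC(=O)/C=C/S(=O)(=O)c4ccccc4OC)cc3F)ccnc2cc1OCCCN1CCCCC1` is the unmeasured member. It differs from compound 2 on a saturated chain carbon, three bonds along the chain from an oxygen on an aromatic ring: piperidin-1-yl in place of 4-methylpiperazin-1-yl on a saturated chain carbon, three bonds along the chain from an oxygen on an aromatic ring. Among the compounds with values here, no measured step concerns this part of the molecule; the three measured compounds all carry the same chain and the same amine. The set therefore gives no indication of a shift in this assay from this change in either direction, and the working assumption is a step that stays within the scatter.

For compound 4 the expected step is a 1.1-fold higher number from compound 2 to compound 4 (0.05 log units; within the scatter). The estimate for compound 4 in this assay is 300 nM, with a range from 100 nM to 900 nM, widened for the lack of any comparable step.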

Compound 4, half-maximal inhibitory concentration: 660 nM
For compound 4 the middle estimate is 2.2-fold (0.34 log units) below the measured one; measured number inside the range.
By their numbers in this assay, from the lowest: compounds 1 and 2 (each within the scatter of the next); then compound 4; then compound 3.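

Within the data shown here, the amine at the end of the propyl chain is not a silent position in this assay: piperidin-1-yl in place of 4-methylpiperazin-1-yl gives a 2.4-fold higher number from compound 2 to compound 4 (0.39 log units; beyond the scatter), the first step in the set from this part of the molecule. Two separate regions of compound 2 now register in this read-out, the aryl group on the sulfonyl sulfur, with a 6.1-fold higher number from compound 2 to compound 3 (0.79 log units; beyond the scatter), and the amine, where the change leaves one ring nitrogen and 6 heavy atoms in place of two ring nitrogens and 7 heavy atoms. Nothing available on these compounds accounts for the shift.

Going by these compounds, a single pair carries this finding, on the 2-methoxyphenyl sulfone alone, so it remains open whether the same change gives a similar step with the 2-fluorophenyl group of compound 1 or the 4-methoxyphenyl group of compound 3. Also open, on these data alone, is whether the step follows the loss of the second ring nitrogen or of its methyl group, a question that piperazin-1-yl and morpholin-4-yl at this position, or a 2-(piperidin-1-yl)ethyl chain for chain length, would bear on.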